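The source may hold more compounds than are shown below. What is called first, only, known or untested is meant among the compounds shown, and "the series" means these compounds.

In an ADME assay on MT4 cells (Homo sapiens) for cytotoxicity, read by MTT assay, with a stated time of 96 h (on this read-out lower numbers stand for higher toxicity in this test and higher numbers for lower toxicity in this test), compound 1 `Cc1ccc(/N=N/N(C)c2ccccc2)cc1` gives 45000 nM and compound 3 `CN(/N=N/c1ccccc1)c1ccccc1` gives 55000 nM. Going by the values given here, these are the only two numbers, and they lie within the scatter of each other. Compound 2 `Clc1cccc(/N=N/N2CCCC2)c1` reads > 100000 nM, which is a limit and not a number. Compound 4 `Cc1ccc(/N=N/N(CCCN(C)C)c2ccccc2)cc1` differs from compound 1 by 2-(dimethylamino)ethyl in place of hydrogen on a saturated chain carbon bound to a nitrogen on an aromatic ring, or, cut one bond further out, methyl to 3-(dimethylamino)propyl. Among the compounds with values here, the only measured step, a 1.2-fold higher number from compound 1 to compound 3 (0.09 log units; within the scatter), is a change on an aromatic carbon, so it gives no direct measure for this chain. A moderate move to a lower number is tentatively expected in this assay, beyond the scatter, as the estimated 2.3-fold lower number from compound 1 to compound 4 (0.35 log units; beyond the scatter). For compound 4 the expected value is 20000 nM, with an estimated range of 5000 nM to 70000 nM.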

Compound 4, half-maximal cytotoxic concentration: 18000 nM
For compound 4 the middle estimate is 1.1-fold (0.05 log units) above the measured one, and the stated range covers the measured number.
By their numbers in this assay, from the lowest: compound 4; then compounds 1 and 3 (each within the scatter of the next). At a limit, above all of these: compound 2.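

Putting 3-(dimethylamino)propyl in place of methyl gives in this assay a 2.5-fold lower number from compound 1 to compound 4 (0.40 log units; beyond the scatter) and so the first measure for this place on the chain. Going by these compounds alone, it is also the first step beyond the scatter, though a modest one. The earlier step lay on an aromatic carbon and within the scatter, so the change at this place is the only one shown to move the number.

Open, as far as these compounds go, is whether the amine or the chain length alone carries this step, which a plain propyl chain would separate. Compound 2 is a limit and gives no step for this change: the limit of > 100000 nM in this assay, at which 1 of the 4 values shown sits.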